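A Benzyl Group in Place of the Acid Hydrogen

This account rests on a few compounds, and the source may have more. Where it says the series, first, only, none or still open, it means among the compounds named here.

Compound 1 `O=C(O)[C@@H]1CCCN1C(=O)CN(c1nc(Cl)nc2[nH]cnc12)C1CC1` carries a free carboxy group. In a functional assay on the whole organism (Tail, strain ICR) with Mus musculus as the target, in the tail flick test, with a stated time of 60 min, at a dose of 25 umol/kg by the oral route (on this read-out lower numbers stand for a weaker effect and higher numbers for a stronger effect at the one dose given), compound 1 gives 34.9%, the lowest of the three measured numbers; compound 3 `O=C(CN(c1ncnc2c1ncn2C1CCCCO1)C1CC1)N[C@@H](CO)C(=O)OCc1ccccc1` gives 46.7% and compound 2 `N=C(N)NCCC[C@H](NC(=O)CN(c1ncnc2c1ncn2C1CCCCO1)C1CC1)C(=O)OCc1ccccc1` gives 52.4%, both beyond the scatter above it. Compound 4 `O=C(OCc1ccccc1)[C@@H]1CCCN1C(=O)CN(c1nc(Cl)nc2[nH]cnc12)C1CC1` differs from compound 1 by benzyl in place of hydrogen on an oxygen next to a carbonyl group. Within the data shown here, the only measured step, a number 5.7 percentage points lower from compound 2 to compound 3 (within the scatter), alters a different part of the molecule and does not speak to the change from carboxy to benzyloxycarbonyl. Compounds 2 and 3 both carry a benzyloxycarbonyl group and sit higher than compound 1, but they differ from it in several other places, so this is a hint, not a pattern. Compound 4 is therefore expected to show a number 10.1 percentage points higher from compound 1 to compound 4 (beyond the scatter), around 45% within 25% to 65%.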

Compound 4, a percentage reported as activity, at one dose (the size of the read-out at that dose, not a potency): 34.4%
Estimate against measurement, compound 4: 10.6 percentage points above, and the stated range covers the measured number.
By their numbers in this assay, from the lowest: compounds 4 and 1 (each within the scatter of the next); then compounds 3 and 2 (each within the scatter of the next).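

In this assay, among these compounds, benzyl in place of hydrogen on an oxygen next to a carbonyl group gives a number 0.5 percentage points lower from compound 1 to compound 4 (within the scatter) and so offers the first direct reading of this change. On the core of compound 1, swapping carboxy for benzyloxycarbonyl is therefore not enough on its own to move this number beyond the scatter. No supporting data bear on why the two compounds read alike. From the compounds shown here alone, whether a methyl ester or a primary amide at this place would read the same remains open. So does whether carboxy and benzyloxycarbonyl would also read alike on the core of compound 2 or compound 3.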